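Acetyl in Place of Trifluoromethyl on a Diaryl Urea

The source may hold more compounds than are shown below. What is called first, only, known or untested is meant among the compounds shown, and "the series" means these compounds.

Measured compounds:
- compound 1, `CCCCCCc1ccc(NC(=O)N[C@H](C)c2ccccc2)cc1`, 101%
- compound 2, `C[C@@H](NC(=O)Nc1ccc(C(F)(F)F)cc1)c1ccccc1`, 82%

In an ADME assay on the whole organism with Oryza sativa as the target, tested at 10 uM (on this read-out higher numbers stand for a weaker effect at the one concentration tested and lower numbers for a stronger effect), compound 2 gives the lower of the two numbers, with compound 1 standing higher by a step beyond the scatter, a number 19 percentage points lower from compound 1 to compound 2 (beyond the scatter). Compound 3, `CC(=O)c1ccc(NC(=O)N[C@H](C)c2ccccc2)cc1`, differs from compound 2 by acetyl in place of trifluoromethyl on an aromatic carbon. For the measured compounds named here, the only measured step, a number 19 percentage points lower from compound 1 to compound 2 (beyond the scatter), concerns the same place on the ring but a different pair of groups, and it was modest; nothing measured speaks directly to acetyl entering there. The account therefore expects at most a small shift in this assay for compound 3, with no clear direction, and the estimated step of a number 4 percentage points higher from compound 2 to compound 3 (within the scatter) is taken to lie within the scatter. Compound 3 is accordingly estimated at 86%, in a range from 66% to 106%.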

Compound 3, a percentage reported as activity, at one concentration (the size of the read-out at that concentration, not a potency): 84%
Estimate against measurement, compound 3: 2 percentage points above; the range from low to high includes it.
By their numbers in this assay, from the lowest: compounds 2 and 3 (each within the scatter of the next); then compound 1.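

At this aromatic carbon, acetyl and trifluoromethyl cannot be told apart in this assay: the exchange gives a number 2 percentage points higher from compound 2 to compound 3 (within the scatter) even though acetyl brings a hydrogen-bond acceptor and trifluoromethyl brings none. Hexyl now stands apart from two different replacements rather than one, since acetyl in its place gives a number 17 percentage points lower from compound 1 to compound 3 (beyond the scatter) and the earlier step with trifluoromethyl is therefore not peculiar to that group among these three compounds. Nothing available bears on the reason for these numbers.

On these data alone, whether the level shared by compound 2 and compound 3 is as low as this position goes remains open, as does what an amine, a carboxylic acid or an ethyl chain would do there. The compounds shown also leave open whether the same holds when the rest of the core changes.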